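Nitroimidazooxazine series: cytotoxicity on MRC5 cells

The source may report more compounds than this note shows. Statements on the series, on what has been measured and on what is new or still open speak of the compounds shown alone.

Compound 2 `O=C(OCC1CCn2cc([N+](=O)[O-])nc2O1)N1CCN(c2ccc(F)cc2)CC1` is the reference for this step. In an ADME assay on MRC5 cells (Homo sapiens) for cytotoxicity, read by resazurin assay, with a stated time of 72 h (a higher number here means a weaker inhibitor, a lower number a stronger inhibitor), compound 2 gives only a limit, > 64000 nM, not a number. Compound 1 `CC1(COc2ccc(-c3ccc(F)nc3F)cn2)CCn2cc([N+](=O)[O-])nc2O1` is capped in the same way. In this assay compound 1 gives the limit > 64000 nM. Compound 3 `O=[N+]([O-])c1cn2c(n1)OC(COc1ccc(-c3ccc(F)nc3)cc1)CC2` behaves likewise. In this assay compound 3 gives the limit > 64000 nM. Every value shown so far is therefore a limit, and compound 2 stands with the other two at the limit of > 64000 nM in this assay, at which 3 of the 3 values shown sit; nothing in the numbers separates them. Among the measured compounds shown here, no step between measured compounds can be read, so the data give no measured size of any change in this assay.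

Compound 4 `CC1(COC(=O)N2CCN(c3ccc(F)cc3)CC2)CCn2cc([N+](=O)[O-])nc2O1` differs from compound 2 by methyl in place of hydrogen on a saturated ring carbon. The step that the limit leaves unreadable from compound 2 to compound 4 is estimated as none beyond the scatter, all three measured compounds having reached the limit (the limit of > 64000 nM in this assay, at which 3 of the 3 values shown sit). Compound 4 is expected to give about 80000 nM in this assay, within 40000 nM to 200000 nM, and most likely to be reported again only as a limit.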

Compound 4, half-maximal inhibitory concentration: > 64000 nM
Compound 4: a limit, no number (the forecaster's own chance of this, stated with the estimate: 85%); the middle value does not contradict the limit.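

Compound 2 and compound 4 both give only limits, so no step between them can be read: the limit of > 64000 nM in this assay, at which 4 of the 4 values shown sit.

The compounds shown leave open whether methyl in place of hydrogen on a saturated ring carbon changes the result at all in this assay.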